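A few compounds are considered here, and "the series" means these few. Any claim that something is new, unique, unknown or untested is made for them only; others in the source may bear on it.

Measured in a functional assay on CCRF-CEM cells (Homo sapiens), read by MTT assay, with a stated time of 72 h; a higher number here means a weaker inhibitor, a lower number a stronger inhibitor:
- Compound 1 `Nc1nc(N)c2c(-c3cc4ccccc4o3)cn([C@@H]3O[C@H](CO)[C@@H](O)[C@H]3O)c2n1`: > 20000 nM
- Compound 2 `Cc1nc(N)c2c(-c3cccs3)cn([C@@H]3O[C@H](CO)[C@@H](O)[C@H]3O)c2n1`: > 20000 nM
- Compound 3 `COc1nc(N)nc2c1c(-c1ccoc1)cn2[C@@H]1O[C@H](CO)[C@@H](O)[C@H]1O`: > 20000 nM

Each of these readings is a limit and not a number.

Compound 3 gives > 20000 nM, which is a limit. It therefore has no measured potency to serve as a starting point, and the other two compounds offer no numerical reference either: the limit of > 20000 nM in this assay, at which 3 of the 3 values shown sit.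

The next compound is compound 4 `COc1nc(N)nc2c1c(-c1cc3ccccc3o1)cn2[C@@H]1O[C@H](CO)[C@@H](O)[C@H]1O`, which carries 1-benzofuran-2-yl in place of furan-3-yl on an aromatic carbon.

Within the data shown here, the series contains no measured step, so the expectation rests on the limits alone. Compound 1 also carries 1-benzofuran-2-yl and gives > 20000 nM, again a limit. No shift beyond the usual scatter is expected in this assay, in either direction, and another reading at the limit is the likeliest outcome. The expected change is a number no higher from compound 3 to compound 4 (the limit leaves the size open). The estimate for compound 4 is 20000 nM, with an expected range of 8000 nM to 40000 nM.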

Compound 4, half-maximal inhibitory concentration: 12700 nM
Compound 4: middle estimate off by 1.6-fold (0.20 log units), on the high side, within the range that was stated.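

In this assay, among these compounds, compound 4 gives 12700 nM, the first reading that is a number and not a limit. At the aromatic carbon two ring bonds from the ring nitrogen, 1-benzofuran-2-yl in place of furan-3-yl gives an at least 1.5-fold lower number from compound 3 to compound 4 (0.19 log units; that floor lies within the scatter), and methoxy in place of amino on an aromatic carbon of the shared core gives an at least 1.5-fold lower number from compound 1 to compound 4 (0.19 log units; that floor lies within the scatter). Neither floor separates its change from the scatter, and the series still sits mostly at one ceiling: the limit of > 20000 nM in this assay, at which 3 of the 4 values shown sit.

Among the compounds shown here, the true size of both steps stays open, since the only readings for the two starting compounds are limits. Also open, as far as these compounds go, is whether a larger aromatic group such as naphthalen-2-yl at that carbon, or dimethylamino in place of methoxy, would give a reading clearly apart from compound 4.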